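A few compounds are considered here, and "the series" means these few. Any claim that something is new, unique, unknown or untested is made for them only; others in the source may bear on it.

Values so far in an ADME assay on the whole organism (Mus musculus, strain ICR(CD-1)) for pharmacokinetics, read by mass spectrometry, at a dose of 10 mg/kg by the oral route; on this read-out lower numbers stand for lower exposure and higher numbers for higher exposure at the dose given
- compound 1 `Cc1ccc(C(=O)Nc2cccc(C(F)(F)F)c2)cc1-c1ccc2c(-c3cnn(C)c3)n[nH]c2c1` gives 3490 ng.h/mL
- compound 2 `Cc1ccc(C(=O)Nc2cccc(C(F)(F)F)c2)cc1-c1ccc2c(-c3cnn(C4CC4)c3)n[nH]c2c1` gives 7680 ng.h/mL

For the measured compounds named here, compound 2 stands highest of the two numbers so far, above compound 1. Compound 3 `Cc1ccc(C(=O)Nc2cccc(C(F)(F)F)c2)cc1-c1ccc2c(-c3cnn(CC(C)O)c3)n[nH]c2c1` keeps the shared core and alters one group: 2-hydroxypropyl in place of cyclopropyl on an aromatic nitrogen. Put simply, this is 2-hydroxypropyl in place of cyclopropyl on an aromatic nitrogen. Going by the values given here, only one measured step bears on this place. Cyclopropyl in place of methyl on an aromatic nitrogen gave a 2.2-fold higher number from compound 1 to compound 2 (0.34 log units; beyond the scatter), and this modest step is the sole guide to size. Among the compounds with values here, its reversal is not being tested, and no compound carrying 2-hydroxypropyl has been measured, so the direction remains uncertain. A downward step of similar size is expected, though it could stay within the scatter. The estimate is a 2.3-fold lower number from compound 2 to compound 3 (0.37 log units; beyond the scatter). For compound 3 the estimated value is 3300 ng.h/mL, within a range of 1200 ng.h/mL to 8000 ng.h/mL.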

Compound 3, area under the concentration-time curve: 334 ng.h/mL
Beside the measured number, compound 3's estimate is 9.9-fold (0.99 log units) above it; the measured number lies below the stated range.
By their numbers in this assay, from the lowest: compound 3; then compound 1; then compound 2.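

Changing the group on this aromatic nitrogen can shift the numbers in this assay much further than the earlier pair showed: 2-hydroxypropyl gives a 23-fold lower number from compound 2 to compound 3 (1.36 log units; beyond the scatter), a large step. The fall is not tied to cyclopropyl alone, as the comparison with the methyl group gives a 10-fold lower number from compound 1 to compound 3 (1.02 log units; beyond the scatter), so compound 3 lies below both compounds with a simpler group. No measurement at hand explains why the number falls so far.

Still open, as far as these compounds go, is whether the hydroxyl group or the open chain matters more, and a plain propyl chain, with no oxygen, would help separate the two. From the compounds shown here alone, it is also open whether an amine or a carboxylic acid on this nitrogen would give numbers as low as those of compound 3.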